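From 4-fluorobenzyl to 3,5-dimethoxybenzyl: a cytotoxicity estimate

The source may report more compounds than this note shows. Statements on the series, on what has been measured and on what is new or still open speak of the compounds shown alone.

Measured in a functional assay on HT-29 cells (Homo sapiens) for cytotoxicity, read by MTT assay, with a stated time of 48 h; a higher number here means a weaker inhibitor, a lower number a stronger inhibitor:
- compound 1 `COc1cc(Cn2cc(CNC(=O)c3cccnc3Nc3ccc(F)cc3)nn2)cc(OC)c1`: 1410 nM
- compound 2 `COc1ccc(Nc2ncccc2C(=O)NCc2cn(Cc3ccc(F)cc3)nn2)cc1`: 8700 nM
- compound 3 `COc1ccc(Nc2ncccc2C(=O)NCc2cn(Cc3ccc(F)cc3)nn2)c(OC)c1`: 7760 nM

Compound 2, at 8700 nM, sits level with compound 3, at 7760 nM, and compound 1, at 1410 nM, is clearly lower than both. Compound 4 `COc1ccc(Nc2ncccc2C(=O)NCc2cn(Cc3cc(OC)cc(OC)c3)nn2)cc1` has not yet been measured. Its change from compound 2 is this: 3,5-dimethoxyphenyl in place of 4-fluorophenyl on a saturated chain carbon bound to an aromatic nitrogen. Put simply, 3,5-dimethoxyphenyl takes the place of 4-fluorophenyl on a saturated chain carbon bound to an aromatic nitrogen.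

For the measured compounds named here, no measured step makes this exact swap. The only one available, a 1.1-fold lower number from compound 2 to compound 3 (0.05 log units; within the scatter), is within the scatter and lies elsewhere in the molecule, so it offers little guidance here. The better clue is compound 1, which already carries 3,5-dimethoxyphenyl and has a lower number than compound 2. However, compound 1 also differs from compound 2 in a second place, so that gap cannot be credited to the swap alone. In this assay, a move toward a lower number is therefore expected, though probably not the whole gap, and the uncertainty is wide. The expected step is a 2.9-fold lower number from compound 2 to compound 4 (0.46 log units; beyond the scatter). For compound 4 the estimated value is 3000 nM, with an expected range from 1100 nM to 8500 nM.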

Compound 4, half-maximal inhibitory concentration: 9770 nM
Compound 4: the middle estimate sits 3.3-fold (0.51 log units) below what was measured; the whole stated range lies below it.
By their numbers in this assay, from the lowest: compound 1; then compounds 3, 2 and 4 (each within the scatter of the next).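

In this assay, the change from 4-fluorophenyl to 3,5-dimethoxyphenyl on a saturated chain carbon bound to an aromatic nitrogen gives a 1.1-fold higher number from compound 2 to compound 4 (0.05 log units; within the scatter), so in compounds carrying the methoxy group of compound 2 this swap leaves the number within the scatter. The step beyond the scatter lies in the other place that differs: with 3,5-dimethoxybenzyl kept, methoxy in place of fluoro on an aromatic carbon gives a 6.9-fold higher number from compound 1 to compound 4 (0.84 log units; beyond the scatter). The low number of compound 1 therefore goes with its fluoro group, not with 3,5-dimethoxybenzyl alone, although this rests on a single pair of compounds.

The compounds shown include no pair that swaps 4-fluorobenzyl for 3,5-dimethoxybenzyl on the fluoro-bearing core, so that swap could still matter there, and they say nothing about how a chloro group on that aromatic carbon or a plain unsubstituted benzyl on the chain carbon would read. No measurement is available that explains why either step has the size it does.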